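The source may hold more compounds than are shown below. What is called first, only, known or untested is meant among the compounds shown, and "the series" means these compounds.

Measured so far in a functional assay on HeLa cells (Homo sapiens) for antiproliferative activity, read by MTT assay, with a stated time of 48 h; a higher number here means a weaker inhibitor, a lower number a stronger inhibitor:
- Compound 1 `Cc1ccc(S(=O)(=O)Nc2ccc3ncc(-c4cnn(C)c4)cc3n2)cc1`: > 50000 nM, a limit
- Compound 2 `Cn1cc(-c2cnc3ccnc(NS(=O)(=O)c4ccc(C(F)(F)F)cc4)c3c2)cn1`: > 50000 nM, a limit

Neither compound gives a number, and the series stands at the limit of > 50000 nM in this assay, at which 2 of the 2 values shown sit. Compound 2 therefore has only a limit as its position. Compound 3 `Cc1ccc(S(=O)(=O)Nc2nccc3ncc(-c4cnn(C)c4)cc23)cc1` carries methyl in place of trifluoromethyl on an aromatic carbon, para to a large group: methyl in place of trifluoromethyl on an aromatic carbon. No measured step sizes this change. Compound 1 also carries 4-methylphenyl and gives only a limit, > 50000 nM. The expected change is a number no higher from compound 2 to compound 3 (the limit leaves the size open), with no step beyond the scatter in this assay. For compound 3 the estimated value is 50000 nM, with an expected range from 20000 nM to 100000 nM.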

Compound 3, half-maximal inhibitory concentration: > 50000 nM
Compound 3 ended at the assay's limit; the forecaster's own chance of this, stated with the estimate: 75%; the middle value lies on the limit itself.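

Compound 2 and compound 3 both end at a limit in this assay, so no step can be read for methyl in place of trifluoromethyl. The compounds shown leave open how any change within this series shifts activity: the limit of > 50000 nM in this assay, at which 3 of the 3 values shown sit.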